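Triazole series: methoxy for methyl in cytotoxicity screen

The source may report more compounds than this note shows. Statements on the series, on what has been measured and on what is new or still open speak of the compounds shown alone.

Measured so far:
compound 1 `CC[C@H](CCn1cncn1)c1ccc(OC)cc1`: 153 ug/mL
compound 2 `CCC[C@H](CCn1cncn1)c1ccccc1`: 58.4 ug/mL
compound 3 `CCC[C@H](CCn1cncn1)c1ccc(C)cc1`: 45.7 ug/mL

For the measured compounds named here, in an ADME assay on HEp-2 cells (Homo sapiens) for cytotoxicity, read by MTT assay, with a stated time of 3 days (on this read-out lower numbers stand for higher toxicity in this test and higher numbers for lower toxicity in this test), compound 3 gives 45.7 ug/mL, the lowest of the three numbers; compound 2 is nearest, and the one step measured in this assay, a 1.3-fold lower number from compound 2 to compound 3 (0.11 log units; within the scatter), lies within the scatter. Compound 1 stands furthest off, beyond the scatter, but it differs from compound 3 in more than one place, so no single step can be read from it.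

The next compound is compound 4 `CCC[C@H](CCn1cncn1)c1ccc(OC)cc1`. It differs from compound 3 by methoxy in place of methyl on an aromatic carbon. Going by the values given here, no measured step bears directly on this exchange: the only step in hand, from compound 2 to compound 3, concerns methyl in place of hydrogen and was within the scatter. Compound 1, which carries the same methoxy group but differs elsewhere, gives 153 ug/mL. With so little to go on, the step of a 1.5-fold higher number from compound 3 to compound 4 (0.19 log units; within the scatter) is expected to stay near or within the scatter, leaning toward a higher number. Compound 4 is therefore estimated at 70 ug/mL, with a range from 35 ug/mL to 140 ug/mL.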

Compound 4, half-maximal cytotoxic concentration: 59.6 ug/mL
For compound 4 the middle estimate is 1.2-fold (0.07 log units) above the measured one, and the stated range covers the measured number.
By their numbers in this assay, from the lowest: compounds 3, 2 and 4 (each within the scatter of the next); then compound 1.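

At the aromatic carbon para to a large group, in this assay the three substituents are not told apart: there is a 1.3-fold higher number from compound 3 to compound 4 (0.12 log units; within the scatter) and also a 1.0-fold higher number from compound 2 to compound 4 (0.01 log units; within the scatter), so hydrogen, methyl and methoxy all sit within the scatter of one another on the shared core. For the compounds shown here, the saturated chain gives the first single-place step beyond the scatter, with the methoxy group held fixed: there is a 2.6-fold lower number from compound 1 to compound 4 (0.41 log units; beyond the scatter) for methyl in place of hydrogen on a saturated chain carbon, though this rests on this one pair alone. No supporting evidence bears on either result.

Still open, as far as these compounds go, is whether an amine or a carboxylic acid at the same aromatic carbon would move the number beyond the scatter. Also open, from the compounds shown here alone, is how a longer chain would read in this cytotoxicity test.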